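A few compounds are considered here, and "the series" means these few. Any claim that something is new, unique, unknown or untested is made for them only; others in the source may bear on it.

Compound 3 `Cc1cccc(CSc2ncnc3c2ncn3[C@@H]2O[C@H](CO)[C@@H](O)[C@H]2O)c1` sits second highest of the three numbers measured in an assay on isolated protein for inhibition of Equilibrative nucleoside transporter 1 (Homo sapiens) (a lower number here means a stronger inhibitor, a higher number a weaker inhibitor), where compound 3 gives 16.2 nM. Its nearest neighbour is compound 1 `N#Cc1cccc(CSc2ncnc3c2ncn3[C@@H]2O[C@H](CO)[C@@H](O)[C@H]2O)c1`, for which compound 1 gives 36.3 nM; the furthest is compound 2 `O=[N+]([O-])c1cccc(CSc2ncnc3c2ncn3[C@@H]2O[C@H](CO)[C@@H](O)[C@H]2O)c1`, where compound 2 gives 1.78 nM. The step to compound 4 `OC[C@H]1O[C@@H](n2cnc3c(SCc4ccc(Cl)cc4Cl)ncnc32)[C@H](O)[C@@H]1O` changes the group on the saturated chain carbon bound to a sulfur: 2,4-dichlorophenyl in place of 3-methylphenyl on a saturated chain carbon bound to a sulfur. Among the compounds with values here, no measured step swaps a methyl for chlorines, so the measured steps bear on it only indirectly, by showing how much the ring's substituent can move the number: a 20-fold lower number from compound 1 to compound 2 (1.31 log units; beyond the scatter), a 2.2-fold lower number from compound 1 to compound 3 (0.35 log units; beyond the scatter) and a 9.1-fold higher number from compound 2 to compound 3 (0.96 log units; beyond the scatter). Within this span, a change of two ring substituents is expected to shift the number only modestly, and a modest lowering is expected here, a 1.6-fold lower number from compound 3 to compound 4 (0.21 log units; within the scatter), with the direction uncertain. Compound 4 is therefore estimated at 10 nM in this assay, in a range from 3 nM to 40 nM.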

Compound 4, inhibition constant: 4.37 nM
Compound 4: the middle estimate sits 2.3-fold (0.36 log units) above what was measured, and the stated range covers the measured number.
By their numbers in this assay, from the lowest: compound 2; then compound 4; then compound 3; then compound 1.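

In this assay, placing 2,4-dichlorophenyl on the saturated chain carbon bound to a sulfur gives a 3.7-fold lower number from compound 3 to compound 4 (0.57 log units; beyond the scatter), so this position accepts a ring with two chlorines and gives a lower number with it than with 3-methylphenyl. The same ring gives an 8.3-fold lower number from compound 1 to compound 4 (0.92 log units; beyond the scatter) against 3-cyanophenyl, but a 2.5-fold higher number from compound 2 to compound 4 (0.39 log units; beyond the scatter) against 3-nitrophenyl. The new ring therefore falls inside the span set by the earlier rings, and 3-nitrophenyl still gives the lowest number of the four.

Nothing available explains this order. From the compounds shown here alone, what each chlorine contributes alone stays open, as does whether an amine or a carboxylic acid on the ring, or a longer chain at the sulfur, would keep the number this low.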